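A few compounds are considered here, and "the series" means these few. Any claim that something is new, unique, unknown or untested is made for them only; others in the source may bear on it.

In a physicochemical assay for solubility, read by HPLC, using the shake flask method, measured as kinetic solubility, with a stated time of 2 h, at pH 7.4 (on this read-out lower numbers stand for lower solubility and higher numbers for higher solubility), three compounds have already been examined. Compound 1 `Cc1cc(NCCCc2ccccn2)n2nc(C)c(-c3ccccc3)c2n1` gives a measured value of 5900 nM there. Compound 2 `Cc1cc(NCc2ccccn2)n2ncc(-c3ccc(C(F)(F)F)cc3)c2n1` returns only a limit, reported as < 5000 nM in this assay. Compound 3 `Cc1cc(NCc2ccccn2)n2ncc(-c3cccc(Cl)c3)c2n1` likewise returns only a limit, reported as < 5000 nM in this assay. So compound 3 stands not on a number but at the limit of < 5000 nM in this assay, at which 2 of the 3 values shown sit, and no measured step between any two of these compounds is available, because the readings of compound 2 and compound 3 stop at that limit.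

Compound 4 `Cc1cc(NCc2ccccn2)n2ncc(-c3ccsc3)c2n1` has not yet been measured. It differs from compound 3 at one place, (thiophen-3-yl in place of 3-chlorophenyl on an aromatic carbon). Among the measured compounds shown here, since no step among the measured compounds can be read off, the size of this change in this assay is uncertain; the expectation is a small shift, if any, and most likely toward the higher side rather than a loss beyond the scatter. The step from compound 3 to compound 4 is therefore expected to be an at least 1.2-fold higher number from compound 3 to compound 4 (0.07 log units; that floor lies within the scatter). For compound 4 the estimated solubility in this assay is 6000 nM, with a range from 2500 nM to 14000 nM, and a fair chance that the measurement again ends at a limit.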

Compound 4, solubility: 9000 nM
For compound 4 the middle estimate is 1.5-fold (0.18 log units) below the measured one; the measured number falls inside the stated range.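

In this assay, among the compounds shown here, thiophen-3-yl on this aromatic carbon of the five-membered ring gives the first reading at this position that is a number and not a limit: compound 4 gives 9000 nM. Set against a limit, the change can only be given as a floor, which is an at least 1.8-fold higher number from compound 3 to compound 4 (0.25 log units; that floor lies within the scatter); the change may be larger, but the floor alone does not clear the ordinary spread of repeat measurements. The earlier compounds carrying other aromatic rings at this position offered no number to work from, as their readings stopped at one shared limit: the limit of < 5000 nM in this assay, at which 2 of the 4 values shown sit.

The true value of compound 3 remains unknown, so the full size of this step stays open, and the other steps among these compounds cannot be read at all. Also open is how this assay would read with a ring bearing an amine, or with a carboxylic acid, on this same aromatic carbon, since the groups shown there are all simple aromatic rings with chlorine, trifluoromethyl or sulfur.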